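The source may hold more compounds than are shown below. What is called first, only, known or untested is meant among the compounds shown, and "the series" means these compounds.

Compound 1, `CCCCC1([C@H](O)/C=C/C2CCC(=O)[C@@H]2CCCCCCC(=O)OCC)CCC1`, compound 2, `CCCCC1([C@H](O)/C=C/C2CCC(=O)[C@@H]2CCCCCCC(=O)O)CCC1`, and compound 3, `CCCCC1([C@H](O)/C=C/C2CCC(=O)[C@@H]2CCCCSCC(=O)OCC)CCC1`, share one core and have all been tested in a functional assay on the whole organism (strain Hartley) for inhibition, with Cavia porcellus as the target, with stated times of 15 min and 2 min; on this read-out higher numbers stand for an effect only at larger amounts of compound and lower numbers for an effect already at smaller amounts. In this assay compound 1 gives 0.0151 mg/kg, compound 2 gives 0.0024 mg/kg and compound 3 gives 0.03 mg/kg. Compound 3 thus stands highest of the three: its nearest neighbour is compound 1, with a 2.0-fold higher number from compound 1 to compound 3 (0.30 log units; within the scatter), and its furthest is compound 2, with a 13-fold higher number from compound 2 to compound 3 (1.10 log units; beyond the scatter). Compound 4, `CCCCC1([C@H](O)/C=C/C2CCC(=O)[C@@H]2CCCCSCC(=O)O)CCC1`, has not yet been measured in this assay. It differs from compound 3 in one place: hydrogen in place of ethyl on an oxygen next to a carbonyl group. The same change has been seen once before, between compound 1 and compound 2, where it gave a 6.3-fold lower number from compound 1 to compound 2 (0.80 log units; beyond the scatter). On that single precedent the step from compound 3 to compound 4 is expected to run in the same direction and at a similar size, namely a 6.3-fold lower number from compound 3 to compound 4 (0.80 log units; beyond the scatter). Compound 4 is therefore estimated to give 0.0048 mg/kg in this assay, with a range from 0.002 mg/kg to 0.012 mg/kg.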

Compound 4, dose for half-maximal effect: 0.0912 mg/kg
For compound 4 the middle estimate is 19-fold (1.28 log units) below the measured one, outside the stated range (above it).
By their numbers in this assay, from the lowest: compound 2; then compounds 1 and 3 (each within the scatter of the next); then compound 4.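

In this assay, the change from ethoxycarbonyl to carboxy does not keep its direction once the chain carries the sulfanyl group, as the step to the acid now runs upward (a 3.0-fold higher number from compound 3 to compound 4 (0.48 log units; beyond the scatter)), so the earlier single step cannot be treated as general: the same change on two cores in this assay, a 6.3-fold lower number (0.80 log units; beyond the scatter) from compound 1 to compound 2 and a 3.0-fold higher number (0.48 log units; beyond the scatter) from compound 3 to compound 4, 19-fold (1.28 log units) apart, beyond the scatter of two such steps. The two chains differ far more as acids than as ethyl esters, since the step between the acids is large (a 38-fold higher number from compound 2 to compound 4 (1.58 log units; beyond the scatter)), whereas the step between the esters lies within the scatter (a 2.0-fold higher number from compound 1 to compound 3 (0.30 log units; within the scatter)). Compound 4 also stands apart from the ester on the all-carbon chain (a 6.0-fold higher number from compound 1 to compound 4 (0.78 log units; beyond the scatter)).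

The compounds shown leave open whether a chain with an ether oxygen in place of the sulfur would behave like compound 2 or like compound 4. They also leave open how a longer chain bearing the carboxylic acid, or a primary amide in its place, would fall in this assay.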